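This account rests on a few compounds, and the source may have more. Where it says the series, first, only, none or still open, it means among the compounds named here.

In a functional assay on COR-L23 cells (Homo sapiens) for antiproliferative activity, read by CellTiter-Glo, with a stated time of 72 h (on this read-out lower numbers stand for stronger inhibition and higher numbers for weaker inhibition), compound 1 (`C[C@@H](c1ccc(NC(=O)N2CC(c3cccnc3)C2)cc1)N1Cc2ccccc2C1=O`) gives 8 nM while compound 2 (`C[C@H](NC(=O)c1ncccn1)c1ccc(NC(=O)N2CC(c3cccnc3)C2)cc1`) gives 130 nM and compound 3 (`CCC(=O)N[C@@H](C)c1ccc(NC(=O)N2CC(c3cccnc3)C2)cc1`) gives 120 nM in the same read-out. Compound 2 thus stands with compound 3 at the high end of these numbers, well clear of compound 1. Compound 4 (`C[C@H](NC(=O)c1ncccn1)c1ccc(NC(=O)N2CC(c3cncc(N)c3)C2)cc1`) differs from compound 2 by a single change: amino in place of hydrogen on an aromatic carbon (amino in place of hydrogen on an aromatic carbon, pyridin-3-yl to 5-aminopyridin-3-yl). Of the measured steps, a 16-fold higher number from compound 1 to compound 2 (1.21 log units; beyond the scatter) and a 15-fold higher number from compound 1 to compound 3 (1.18 log units; beyond the scatter) are large, whereas a 1.1-fold lower number from compound 2 to compound 3 (0.03 log units; within the scatter) stays within the scatter. None of them alters the pyridin-3-yl group, so they show how far numbers can move in this series but give no direct size for the amino change. No step beyond the scatter is therefore expected, though the uncertainty is wide, and the estimated step is a 1.5-fold higher number from compound 2 to compound 4 (0.19 log units; within the scatter) in this assay on this limited evidence. For compound 4 the estimate is 200 nM with an expected range of 50 nM to 800 nM in that read-out.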

Compound 4, half-maximal inhibitory concentration: 1380 nM
Estimate against measurement, compound 4: 6.9-fold (0.84 log units) below; the whole stated range lies below it.
By their numbers in this assay, from the lowest: compound 1; then compounds 3 and 2 (each within the scatter of the next); then compound 4.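

In this assay, the pyridin-3-yl group proves sensitive to substitution: amino in place of hydrogen on the aromatic carbon two atoms from the ring nitrogen gives an 11-fold higher number from compound 2 to compound 4 (1.03 log units; beyond the scatter). This single added heavy atom produces a large step, as does the much larger exchange of groups in a 16-fold higher number from compound 1 to compound 2 (1.21 log units; beyond the scatter), so this end of the molecule also has a strong hold on the number in this series. No measurement shown here bears on the reason for the weaker inhibition.

Going by these compounds, whether a methyl group, a hydroxyl group or a fluorine atom at the same position would give a similar step remains open. Also open, on these data alone, is whether the amino group would carry the same penalty alongside the side chains of compound 1 or compound 3.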